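Ortho substituents on the sulfonyl aryl ring and kallikrein-7

The source may report more compounds than this note shows. Statements on the series, on what has been measured and on what is new or still open speak of the compounds shown alone.

Compound 1 `CC1=NC(c2cn(S(=O)(=O)c3ccc(Cl)cc3)c3ccc(C)cc23)CN1`: > 100000 nM
Compound 2 `CC1=NC(c2cn(S(=O)(=O)c3cccc(Cl)c3)c3ccc(C)cc23)CN1`: 10000 nM
Compound 3 `CC1=NC(c2cn(S(=O)(=O)c3ccccc3C)c3ccc(C)cc23)CN1`: 1300 nM

Three compounds share one core and differ only in the aryl group on the sulfonyl sulfur. In an assay on isolated protein for inhibition of kallikrein-7 (Mus musculus), read by fluorescence, with stated times of 10 min and 30 min (a higher number here means a weaker inhibitor, a lower number a stronger inhibitor), compound 1 reaches only a limit, > 100000 nM (the limit of > 100000 nM in this assay, at which 1 of the 3 values shown sits). Among the numbers proper, compound 2 stands highest; its nearest neighbour is compound 3, which lies lower by a 7.7-fold lower number from compound 2 to compound 3 (0.89 log units; beyond the scatter). Compound 4 `CC1=NC(c2cn(S(=O)(=O)c3ccccc3Br)c3ccc(C)cc23)CN1` has not been measured; its change from compound 2 is 2-bromophenyl in place of 3-chlorophenyl on a sulfonyl sulfur. The step of a 7.7-fold lower number from compound 2 to compound 3 (0.89 log units; beyond the scatter) bears most directly on it, with an at least 76-fold lower number from compound 1 to compound 3 (1.88 log units; beyond the scatter) pointing the same way, so a modest drop in the number is expected, a 5.0-fold lower number from compound 2 to compound 4 (0.70 log units; beyond the scatter). Compound 4 is therefore estimated at 2000 nM, with a range from 600 nM to 7000 nM.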

Compound 4, half-maximal inhibitory concentration: 400 nM
For compound 4 the middle estimate is 5.0-fold (0.70 log units) above the measured one; measured number below the stated range.
By their numbers in this assay, from the lowest: compound 4; then compound 3; then compound 2. At a limit, above all of these: compound 1.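

In this assay the bromo group goes further than the methyl it replaces on the aromatic carbon, with a 3.3-fold lower number from compound 3 to compound 4 (0.51 log units; beyond the scatter), so the gain seen with 2-methylphenyl does not depend on methyl itself. Set against the chlorophenyl groups, 2-bromophenyl gives a 25-fold lower number from compound 2 to compound 4 (1.40 log units; beyond the scatter) and an at least 250-fold lower number from compound 1 to compound 4 (2.39 log units; beyond the scatter). The second of these steps starts from a limit for compound 1: the limit of > 100000 nM in this assay, at which 1 of the 4 values shown sits.

Because compound 4 differs from compound 2 in both halogen and its location, the compounds shown do not separate these two changes. As far as these compounds go, whether a 2-methoxyphenyl or 2-trifluoromethylphenyl group would follow 2-bromophenyl remains open.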